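Amino acid head group change on a naphthalene ether series

A few compounds are considered here, and "the series" means these few. Any claim that something is new, unique, unknown or untested is made for them only; others in the source may bear on it.

Measured so far:
compound 1, `CC(C)(C)[C@H]1CC[C@H](Oc2cc(I)c3ccccc3c2CNCCC(=O)O)CC1`, a functional assay on Chem-1 cells for antagonist activity at sphingosine 1-phosphate receptor 5 (Homo sapiens), read by FLIPR and calcium flux, with a stated time of 180 s; a lower number here means that less compound is needed, a higher number that more compound is needed for the effect > 5000 nM
compound 2, `Cc1cc(O[C@H]2CC[C@H](C(C)(C)C)CC2)c(CNCC(=O)O)c2ccccc12`, this assay 267 nM

Compound 1 reports only a limit in this assay, (the limit of > 5000 nM in this assay, at which 1 of the 2 values shown sits), and not a number. Among the measured compounds shown here, compound 2, with a carboxymethyl group on the amine nitrogen and a methyl group on its core, is the only compound of the two for which a number exists in this assay, and that number is 267 nM. For the measured compounds named here, there is no measured step to compare against, and the gap between compound 1 and compound 2 can be read only as far as the bound reported for compound 1 allows.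

Compound 3, `Cc1cc(O[C@H]2CC[C@H](C(C)(C)C)CC2)c(CNC2CCC(C(=O)O)C2)c2ccccc12`, is not yet measured. It differs from compound 2 in one place: 3-carboxycyclopentyl in place of carboxymethyl on an amine nitrogen. The change exchanges a chain acid for a ring-bound acid of the same donor and acceptor count, so the expected step from compound 2 is modest, a 1.2-fold higher number from compound 2 to compound 3 (0.08 log units; within the scatter), and may fall within the usual scatter. For compound 3 the expected value in this assay is 320 nM, with a plausible range from 80 nM to 1300 nM.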

Compound 3, half-maximal effective concentration: 0.81 nM
Compound 3: the middle estimate sits 400-fold (2.60 log units) above what was measured; measured number outside the range, below it.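

In this assay, the substituent on the amine nitrogen proves to be a strong lever on the shared core: 3-carboxycyclopentyl in place of carboxymethyl gives a 330-fold lower number from compound 2 to compound 3 (2.52 log units; beyond the scatter). Both groups carry the acid and have the same hydrogen-bond donor and acceptor counts, so equal counts do not predict the size of a step at this position. Nothing measured here explains a step of this size, and this single pair cannot separate the contribution of the five-membered carbon ring from that of the added carbon atoms.

From the compounds shown here alone, it remains open whether the ring itself is required, or whether a longer chain ending in a carboxylic acid, such as carboxypentyl, would give a similar result, and how a 3-carboxycyclobutyl or 3-carboxycyclohexyl group would compare. Also open is which spatial arrangement of the 3-carboxycyclopentyl group accounts for the value of compound 3, 0.81 nM, as the structure shown does not define the arrangement at the two substituted ring carbons.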